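Trimming one chloro from the dichloropyridyl ether

A few compounds are considered here, and "the series" means these few. Any claim that something is new, unique, unknown or untested is made for them only; others in the source may bear on it.

Compound 2 `Cc1cc(C(=O)O)ccc1CN1CCC[C@H](O[C@H](CO)c2cc(Cl)nc(Cl)c2)[C@@H]1c1ccccc1` is the lower of the two numbers measured in an assay on isolated protein for activation of cGMP-dependent protein kinase 1 (Homo sapiens), read by ADP-Glo, with stated times of 30 min and 2 h, in the presence of a further agent that is not named here; a higher number here means that more compound is needed for the effect, a lower number that less compound is needed: compound 2 gives 2400 nM, while compound 1 `Cc1cc(C(=O)O)ccc1CN1CCC[C@H](O[C@H](CO)c2ccccc2)[C@@H]1c1ccccc1` gives 25000 nM. Going by the values given here, the only step between measured compounds, a 10-fold lower number from compound 1 to compound 2 (1.02 log units; beyond the scatter), came from putting 2,6-dichloropyridin-4-yl in place of phenyl on the saturated chain carbon bound to the ether oxygen.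

Compound 3 `Cc1cc(C(=O)O)ccc1CN1CCC[C@H](O[C@H](CO)c2ccnc(Cl)c2)[C@@H]1c1ccccc1` keeps that pyridyl group but carries one chloro fewer: hydrogen in place of chloro on an aromatic carbon. Cut one bond further out, the change reads 2,6-dichloropyridin-4-yl to 2-chloropyridin-4-yl, so the ring nitrogen and one chloro stay.

Among the compounds with values here, the step from compound 1 to compound 2 bears on this directly, since it introduced both chloro groups and the ring nitrogen together; there is no measured step that separates the contribution of a single chloro. Removing one of the two is therefore expected to give back part, not all, of that gain, a modest rise in this assay.

For compound 3 the estimate is 5000 nM, with a range of 1500 nM to 15000 nM, a step of a 2.1-fold higher number from compound 2 to compound 3 (0.32 log units; beyond the scatter) that is expected to fall between the two measured numbers.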

Compound 3, half-maximal effective concentration: 50000 nM
The estimate for compound 3 lay 10-fold (1.00 log units) below the measured number, outside the stated range (above it).
By their numbers in this assay, from the lowest: compound 2; then compounds 1 and 3 (each within the scatter of the next).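

In this assay, this chloro on the aromatic carbon next to the ring nitrogen proves to be worth far more than a share of the earlier gain: replacing it with hydrogen gives a 21-fold higher number from compound 2 to compound 3 (1.32 log units; beyond the scatter), a step larger than the whole of a 10-fold lower number from compound 1 to compound 2 (1.02 log units; beyond the scatter). With the ring nitrogen and the other chloro still present, 2-chloropyridin-4-yl in place of phenyl gives a 2.0-fold higher number from compound 1 to compound 3 (0.30 log units; within the scatter), so this group does not stand apart from phenyl. Among these three compounds, the gain therefore appears only with 2,6-dichloropyridin-4-yl, and the two chloro groups do not contribute equal, separate shares of it.

No measurement here explains why the second chloro has so large an effect. Open questions are whether methyl, bromo or trifluoromethyl could take the place of this chloro, and whether a phenyl ring carrying two chloro groups would keep the gain without the ring nitrogen.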